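Methoxy for Methyl on the Fused Aromatic Ring

The compounds below may be only part of what the source reports. "The series", "measured", "known", "first", "only" and "open" are said of these compounds alone.

Compound 1 `COC(=O)[C@@]1(C)CCC=C2[C@@H]1CC[C@@H](C)[C@]2(C)Cc1c(C)[nH]c2c(Br)cccc12` and compound 2 `COC(=O)[C@@]1(C)CC[C@@H]2C3=C1CC[C@@H](C)[C@]3(C)C[C@@H]1c3cc(C)ccc3N[C@H]21` were both tested in a functional assay on HeLa cells (Homo sapiens) for inhibition, read by sulforhodamine B assay, with a stated time of 48 h; a higher number here means a weaker inhibitor of growth, a lower number a stronger inhibitor of growth. Compound 1 gives 22000 nM, while compound 2 gives 18000 nM, the lower of the two numbers, though its gap to compound 1 is within the scatter. Compound 3 `COC(=O)[C@@]1(C)CC[C@@H]2C3=C1CC[C@@H](C)[C@]3(C)C[C@@H]1c3cc(OC)ccc3N[C@H]21` is not yet measured; it differs from compound 2 by methoxy in place of methyl on an aromatic carbon. No measured step of this kind exists among these compounds, so no change beyond the scatter is expected in this assay, an expected step of a 1.1-fold higher number from compound 2 to compound 3 (0.05 log units; within the scatter). Compound 3 is therefore estimated at 20000 nM, between 8000 nM and 50000 nM.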

Compound 3, concentration for 50% growth inhibition: 20000 nM
For compound 3 middle estimate and measured number coincide at the digits printed, and the stated range covers the measured number.
By their numbers in this assay, from the lowest: compounds 2, 3 and 1 (each within the scatter of the next).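

Read in this assay, methoxy in place of methyl on this aromatic carbon gives a 1.1-fold higher number from compound 2 to compound 3 (0.05 log units; within the scatter), the first step measured at this position, and it lies within the scatter. This one exchange therefore leaves the growth-inhibition number of the shared core unmoved. Nothing available explains this result or links it to any property of either group.

The compounds shown leave open whether an amine, a hydroxyl or a longer chain such as ethoxy on this carbon would move the number beyond the scatter.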